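The source may report more compounds than this note shows. Statements on the series, on what has been measured and on what is new or still open speak of the compounds shown alone.

Measured compounds:
- compound 1, `Fc1cccc(/C=N/NC(=S)Nc2cccc3ccccc23)c1F`: 500 ug/mL
- compound 2, `Fc1cccc(F)c1/C=N/NC(=S)Nc1cccc2ccccc12`: 500 ug/mL

In a functional assay on A549 cells (Homo sapiens) for cytotoxicity, read by XTT assay, with a stated time of 24 h (a lower number here means a stronger inhibitor, a higher number a weaker inhibitor), compound 2 stands level with compound 1; the step of no change at the digits printed from compound 1 to compound 2 (within the scatter) lies within the scatter. Compound 3, `Fc1cc(F)c(/C=N/NC(=S)Nc2cccc3ccccc23)c(F)c1`, differs from compound 2 by fluoro in place of hydrogen on an aromatic carbon. For the measured compounds named here, the only measured step that bears on this, no change at the digits printed from compound 1 to compound 2 (within the scatter), rearranged fluoro groups on the same ring without any shift, so for compound 3 no step beyond the scatter is expected, no change at the digits printed from compound 2 to compound 3 (within the scatter). Compound 3 is therefore estimated at 500 ug/mL, with a range from 250 ug/mL to 1000 ug/mL.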

Compound 3, half-maximal inhibitory concentration: > 500 ug/mL
Compound 3: a limit, no number; the forecaster's own chance of this, stated with the estimate: 25%; the middle value sits exactly at the limit.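

In this assay compound 3 gives > 500 ug/mL, which is a limit and not a number. Where the earlier pair only rearranged fluoro groups on the same ring, this change adds one on an aromatic carbon para to a large group, and the result is a number no lower from compound 2 to compound 3 (the limit leaves the size open). The size of that step cannot be read because the value is a limit: the limit of > 500 ug/mL in this assay, at which 1 of the 3 values shown sits.

The compounds shown leave open how far the value of compound 3 lies from that limit. They also leave open what an amine or a carboxylic acid on this carbon would give.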